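Cytotoxicity notes: aryl replacement at the biaryl terminus

The compounds below may be only part of what the source reports. "The series", "measured", "known", "first", "only" and "open" are said of these compounds alone.

Measured so far, in an ADME assay on BJ cells (Homo sapiens) for cytotoxicity, read by CellTiter-Glo and resazurin assay, with a stated time of 72 h; a higher number here means that more compound is needed for the effect, a lower number that less compound is needed:
- compound 1, `CCOC(=O)CCCCCOc1cccc(CN(C(=O)c2ccc(-c3cccc(OCC(C)C)c3)cc2)C(C)C)c1`, gives > 26000 nM, a limit of the assay.
- compound 2, `CCOC(=O)CCCCCOc1cccc(CN(C(=O)c2ccc(-c3ccc(C(C)=O)s3)cc2)C(C)C)c1`, gives > 26000 nM, also a limit of the assay.

Compound 2 therefore stands only at a limit in this assay, with no number of its own. The step that the two limits leave unreadable from compound 1 to compound 2 cannot be read, since both ends sit at the limit of > 26000 nM in this assay, at which 2 of the 2 values shown sit.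

Compound 3, `CCOC(=O)CCCCCOc1cccc(CN(C(=O)c2ccc(-c3cccc(OCC)c3)cc2)C(C)C)c1`, arises from compound 2 by 3-ethoxyphenyl in place of 5-acetylthiophen-2-yl on an aromatic carbon. For the measured compounds named here, the only step measured bears on this change, and it is unreadable; nothing measured separates the two aryl groups. The expectation is that the step that the limit leaves unreadable from compound 2 to compound 3 brings compound 3 no further than the scatter from where compound 2 stands, so compound 3 is expected to remain at the limit. Compound 3 is estimated at 40000 nM, within a range of 15000 nM to 120000 nM.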

Compound 3, half-maximal effective concentration: > 22300 nM
Compound 3 ended at the assay's limit; the forecaster's own chance of this, stated with the estimate: 85%; the middle value lies beyond the limit too.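

In this assay compound 3 gives > 22300 nM, a limit of the assay. For the compounds shown here, compound 1 and compound 2 also stand at limits, so no step among the three can be read. The compounds shown leave open at what concentration any of them reaches the half-maximal effect, and whether their aryl groups differ at all.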